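This account rests on a few compounds, and the source may have more. Where it says the series, first, only, none or still open, it means among the compounds named here.

Going by the values given here, compound 2, with the structure `CC(C(=O)NCc1ccc(C(F)(F)F)nc1NCc1ccc(Cl)cc1)c1ccc(NS(C)(=O)=O)c(F)c1`, stands second highest of the three numbers measured so far in a functional assay on CHO-K1 cells for antagonist activity at transient receptor potential cation channel subfamily V member 1 (Homo sapiens), read by FLIPR (on this read-out lower numbers stand for stronger inhibition and higher numbers for weaker inhibition), where compound 2 gives 414 nM. Its nearest neighbour is compound 1, `CC(C(=O)NCc1ccc(C(F)(F)F)nc1NCC1CCN(C(=O)OC(C)(C)C)CC1)c1ccc(NS(C)(=O)=O)c(F)c1`, which in this assay gives 1140 nM; the furthest is compound 3, `C[C@H](C(=O)NCc1ccc(C(F)(F)F)nc1N1CCC(c2ccccc2)CC1)c1ccc(NS(C)(=O)=O)c(F)c1`, which in this assay gives 17.4 nM. Both of these gaps lie beyond the usual scatter of repeated measurements.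

Compound 4, `CCCCOC1CCN(c2nc(C(F)(F)F)ccc2CNC(=O)C(C)c2ccc(NS(C)(=O)=O)c(F)c2)CC1`, has not yet been measured. It differs from compound 2 in one place: a group of 11 heavy atoms (9 carbon, 1 nitrogen, 1 oxygen; one six-membered non-aromatic ring with 1 hetero atom) in place of a group of 9 heavy atoms (7 carbon, 1 nitrogen, 1 chlorine; one six-membered aromatic ring of carbon only), on an aromatic carbon. The group that enters attaches its six-membered non-aromatic ring with one hetero atom directly to the aromatic carbon, as compound 3 does, whereas compound 1 and compound 2 each carry a chain between that carbon and their ring.

Since compound 3 gives 17.4 nM in this assay while compound 2 gives 414 nM, a step toward a lower number is expected, though smaller than that gap, as the ring entering in compound 4 carries no aromatic ring. The estimate for compound 4 in this assay is 90 nM, between 20 nM and 400 nM. The expected step is a 4.6-fold lower number from compound 2 to compound 4 (0.66 log units; beyond the scatter).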

Compound 4, half-maximal inhibitory concentration: 28.2 nM
Compound 4: middle estimate off by 3.2-fold (0.50 log units), on the high side, and the stated range covers the measured number.
By their numbers in this assay, from the lowest: compounds 3 and 4 (each within the scatter of the next); then compound 2; then compound 1.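

In this assay, going by these compounds alone, replacing (4-chlorobenzyl)amino on this aromatic carbon, next to the ring nitrogen, gives a 15-fold lower number from compound 2 to compound 4 (1.17 log units; beyond the scatter), the first single change at this position that can be read. It shows that the entering group, with its six-membered non-aromatic ring attached directly to that carbon, needs no six-membered aromatic ring of carbon only to give a large step toward stronger inhibition. No measurement here accounts for the size of this step.

The change removes the chain before the ring and the aromatic ring at once, so the share of each stays unresolved. As far as these compounds go, whether a small open-chain amine such as dimethylamino, or a morpholine ring, would serve on this carbon also remains open.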